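Replacing butylamino with hydroxy on a carbonyl carbon

The compounds below may be only part of what the source reports. "The series", "measured", "known", "first", "only" and "open" are said of these compounds alone.

For the measured compounds named here, in a functional assay (brain) for inhibition, with Rattus norvegicus as the target (on this read-out lower numbers stand for stronger inhibition and higher numbers for weaker inhibition), two compounds sharing one core have numbers so far. Compound 1 `COc1cc2c(cc1O)CCC(C(=O)Nc1ccccc1)O2` gives 6900 nM. Compound 2 `CCCCNC(=O)C1CCc2cc(O)c(OC)cc2O1` gives 51300 nM, the higher of the two numbers and therefore the weaker inhibition. Compound 3 `COc1cc2c(cc1O)CCC(C(=O)O)O2` has not yet been measured and differs from compound 2 in one place: hydroxy in place of butylamino on a carbonyl carbon. In words, hydroxy stands in place of butylamino on a carbonyl carbon, so the amide-type nitrogen is gone along with its chain.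

Going by the values given here, only one measured step bears on this change, and only loosely. It is a 7.4-fold higher number from compound 1 to compound 2 (0.87 log units; beyond the scatter), a modest step beyond the scatter, with butyl in place of phenyl on an amide-type nitrogen. Among the compounds with values here, that step shows that changing the group at this place can move the number, but no measured compound lacks the nitrogen. A further modest rise in this assay is the most reasonable expectation, held with wide uncertainty. The expected change is a 2.3-fold higher number from compound 2 to compound 3 (0.37 log units; beyond the scatter). Compound 3 is estimated at 120000 nM, with an expected range of 40000 nM to 400000 nM.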

Compound 3, half-maximal inhibitory concentration: > 300000 nM
Compound 3: a limit, no number (the forecaster's own chance of this, stated with the estimate: 25%); middle value at least 2.5-fold (0.39 log units) from the limit.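

For compound 3, this assay gives only a limit and not a number: the limit of > 300000 nM in this assay, at which 1 of the 3 values shown sits. Hydroxy in place of butylamino on a carbonyl carbon gives an at least 5.8-fold higher number from compound 2 to compound 3 (0.76 log units; beyond the scatter), and hydroxy in place of anilino at the same carbon gives an at least 43-fold higher number from compound 1 to compound 3 (1.63 log units; beyond the scatter); each step could be larger than these printed minimums. The earlier compounds showed only that changing the group on the amide-type nitrogen can move the number, whereas compound 3 now shows what happens with no such nitrogen: it is the weakest inhibitor of the three, and among these compounds, butylamino and anilino both go with stronger inhibition than hydroxy.

From the compounds shown here alone, it remains open whether the gain comes from the amide-type nitrogen itself or from the butyl or phenyl group it carries, a question that an unsubstituted amide or a methyl ester could help to separate. Also open, going by these compounds, is how a longer chain or a benzyl group on the nitrogen would compare with butyl and phenyl.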